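The source may hold more compounds than are shown below. What is called first, only, known or untested is meant among the compounds shown, and "the series" means these compounds.

In a functional assay on MCF7 cells (Homo sapiens) for antiproliferative activity, read by MTT assay, with a stated time of 24 h (on this read-out higher numbers stand for weaker inhibition and lower numbers for stronger inhibition), compound 1 `FC(F)(F)c1ccc(-c2nn(-c3ccccc3)cc2-c2nc3ccccc3[nH]2)cc1` gives 6330 nM, while compound 2 `Cc1ccc(C)c(S(=O)(=O)n2c(-c3cn(-c4ccccc4)nc3-c3ccc(C(F)(F)F)cc3)nc3ccccc32)c1` gives 170 nM, the lower of the two numbers and so the stronger inhibition measured so far. Compound 3 `O=[N+]([O-])c1ccc(S(=O)(=O)n2c(-c3cn(-c4ccccc4)nc3-c3ccc(C(F)(F)F)cc3)nc3ccccc32)cc1` keeps the sulfonyl group and changes only what the sulfur carries, with 4-nitrophenyl in place of 2,5-dimethylphenyl on a sulfonyl sulfur.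

Among the compounds with values here, only one measured step bears on this change: a 37-fold lower number from compound 1 to compound 2 (1.57 log units; beyond the scatter), which came from (2,5-dimethylphenyl)sulfonyl in place of hydrogen on an aromatic nitrogen. That step is large, but it describes adding the whole group. Within the data shown here, no measured step shows what swapping the ring on the sulfur does, so the evidence here is thin. Compound 3 retains the sulfonyl group that marks the step of a 37-fold lower number from compound 1 to compound 2 (1.57 log units; beyond the scatter), so it is expected to stay much nearer to compound 2 than to compound 1, with a small move towards a higher number and no confident direction. The expected change is a 1.5-fold higher number from compound 2 to compound 3 (0.17 log units; within the scatter). In this assay, the estimate for compound 3 is 250 nM, with an expected range of 80 nM to 800 nM.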

Compound 3, half-maximal inhibitory concentration: 1130 nM
Compound 3: middle estimate off by 4.5-fold (0.66 log units), on the low side, and the stated range ends below it.
By their numbers in this assay, from the lowest: compound 2; then compound 3; then compound 1.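

In this assay the ring on the sulfonyl sulfur matters in its own right: 4-nitrophenyl in place of 2,5-dimethylphenyl gives a 6.6-fold higher number from compound 2 to compound 3 (0.82 log units; beyond the scatter) and this could not be seen from adding the whole group to the core. The (4-nitrophenyl)sulfonyl group still keeps part of the gain over the free aromatic nitrogen, with a 5.6-fold lower number from compound 1 to compound 3 (0.75 log units; beyond the scatter) and this is a smaller step than a 37-fold lower number from compound 1 to compound 2 (1.57 log units; beyond the scatter) so the size of the gain changes with what the sulfur carries. No measurement here explains the difference between the two rings.

The two rings differ in more than one feature, so the compounds shown cannot separate the loss of the methyl groups from the arrival of the nitro group, a question that an unsubstituted phenyl ring or an amine in place of the nitro group could help to settle. Going by these compounds, it also remains open whether an aromatic ring is needed on the sulfur at all, or whether a simple methyl or a longer alkyl chain there would keep the gain.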